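The compounds below may be only part of what the source reports. "The series", "measured", "known", "first", "only" and "open" are said of these compounds alone.

Measured compounds in an assay on HEK293 cells for positive allosteric modulation of metabotropic glutamate receptor 5 (Homo sapiens), read by FLIPR; a higher number here means that more compound is needed for the effect, a lower number that less compound is needed:
compound 1 `Cc1cccc(-c2noc(C3CN(C(=O)c4ccccc4F)C3)n2)c1`, a limit of the assay: > 10000 nM
compound 2 `O=C(c1ccccc1F)N1CC(c2nc(-c3cccc(Cl)c3)no2)C1`, a limit of the assay: > 10000 nM
compound 3 `Cc1cccc(-c2noc(C3CN(S(=O)(=O)c4ccc(Cl)cc4)C3)n2)c1`, a limit of the assay: > 10000 nM

None of the three values is a number; all sit at the limit of > 10000 nM in this assay, at which 3 of the 3 values shown sit. Compound 2 and compound 1 differ by methyl in place of chloro on an aromatic carbon, and the step that the two limits leave unreadable from compound 2 to compound 1. The difference between the cores of compound 2 and compound 3 is not broken down here. Compound 4 `Cc1ccc(S(=O)(=O)N2CC(c3nc(-c4cccc(C)c4)no3)C2)cc1`, not yet measured, differs from compound 3 by methyl in place of chloro on an aromatic carbon. The place is not the same: meta to a large group in compound 2, para to a large group in compound 3, so this is the same kind of change, not the same one. The step from compound 3 to compound 4 is expected to be a step that the limit leaves unreadable from compound 3 to compound 4, resting on compound 3 at the limit of > 10000 nM in this assay, at which 3 of the 3 values shown sit, and on the unreadable earlier step that the two limits leave unreadable from compound 2 to compound 1. Compound 4 is estimated at 15000 nM, between 5000 nM and 50000 nM, most likely again reported only as a limit.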

Compound 4, half-maximal effective concentration: > 10000 nM
Compound 4: only a limit was reported (the forecaster's own chance of this, stated with the estimate: 85%); the middle value does not contradict the limit.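

No step can be read from compound 3 to compound 4, as each reports only a limit of the assay: the limit of > 10000 nM in this assay, at which 4 of the 4 values shown sit.

The compounds shown leave open whether methyl and chloro differ at all once a value falls within the readable range.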